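A few compounds are considered here, and "the series" means these few. Any claim that something is new, unique, unknown or untested is made for them only; others in the source may bear on it.

Working notes on the series. In an ADME assay on MDCK cells (Canis lupus familiaris) for cytotoxicity, read by resazurin assay, with a stated time of 72 h (on this read-out lower numbers stand for higher toxicity in this test and higher numbers for lower toxicity in this test), compound 1 `CCC(=O)NC(=N)N[C@H]1CC(C(=O)O)=C[C@@H](OC(CC)CC)[C@@H]1NC(C)=O` gives > 1000 nM, which is a limit. Compound 2 `CCC(CC)O[C@@H]1C=C(C(=O)O)C[C@H](NC(=N)NC(=O)CCc2ccc(OC)c(OC)c2)[C@H]1NC(C)=O` gives > 1000 nM, also a limit and not a number. Among the compounds with values here, the one measured change is a step that the two limits leave unreadable from compound 1 to compound 2. Compound 3 `CCC(CC)O[C@@H]1C=C(C(=O)O)C[C@H](NC(=N)NC(=O)c2ccc([N+](=O)[O-])cc2)[C@H]1NC(C)=O` carries 4-nitrophenyl in place of 2-(3,4-dimethoxyphenyl)ethyl on a carbonyl carbon. Within the data shown here, compound 2, like compound 1, sits at the limit of > 1000 nM in this assay, at which 2 of the 2 values shown sit, so no step of readable size can be carried over and no step beyond the scatter is expected in this assay. The expected step is a step that the limit leaves unreadable from compound 2 to compound 3. For compound 3 the estimated value is 3000 nM, with an expected range of 1000 nM to 10000 nM.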

Compound 3, half-maximal cytotoxic concentration: > 1000 nM
Compound 3 gave a limit, no number; the forecaster's own chance of this, stated with the estimate: 85%; the middle value lies beyond the limit too.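

No step can be read among compound 1, compound 2 and compound 3 in this assay, because each gives a limit and not a number: the limit of > 1000 nM in this assay, at which 3 of the 3 values shown sit.

The compounds shown leave open where the actual cytotoxic concentration of each lies and whether the group on the carbonyl carbon changes it.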